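Swapping the Para Substituent: Chloro to Methoxy

The source may report more compounds than this note shows. Statements on the series, on what has been measured and on what is new or still open speak of the compounds shown alone.

Measured compounds:
Compound 1, `Cn1c(N2N=C(c3ccccc3)CC2c2ccccc2)nc(-c2ccccc2)c(C#N)c1=O`: 3990 nM
Compound 2, `Cn1c(N2N=C(c3ccccc3)CC2c2ccc(Cl)cc2)nc(-c2ccccc2)c(C#N)c1=O`: 28000 nM

Compound 2 stands at the highest of the two numbers in a functional assay on MDA-MB-231 cells (Homo sapiens) for antiproliferative activity, with a stated time of 72 h; on this read-out lower numbers stand for stronger inhibition and higher numbers for weaker inhibition; its nearest neighbour is compound 1, which gives 3990 nM, a step described as a 7.0-fold higher number from compound 1 to compound 2 (0.85 log units; beyond the scatter). That step is the only measured one, and it changes the same phenyl ring that is altered next: a chloro in place of a hydrogen on an aromatic carbon weakened the inhibition by a modest but clear margin.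

Compound 3, `COc1ccc(C2CC(c3ccccc3)=NN2c2nc(-c3ccccc3)c(C#N)c(=O)n2C)cc1`, has not yet been measured in this assay. It differs from compound 2 by methoxy in place of chloro on an aromatic carbon. Going by the values given here, the substituent at that place is again changed, so the only step that bears on it is the one from compound 1 to compound 2. That step shows the unsubstituted ring doing best so far, but it says nothing direct about how methoxy compares with chloro. A step of uncertain direction, probably within or close to the scatter, is therefore expected.

On that basis compound 3 is estimated at 15000 nM, with a range from 4000 nM to 50000 nM, which would mean an expected step of a 1.9-fold lower number from compound 2 to compound 3 (0.27 log units; within the scatter).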

Compound 3, half-maximal inhibitory concentration: 12800 nM
Beside the measured number, compound 3's estimate is 1.2-fold (0.07 log units) above it; the range from low to high includes it.
By their numbers in this assay, from the lowest: compound 1; then compound 3; then compound 2.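

In this assay, the new result shows that the identity of the group at this place matters, not only whether a group is present: methoxy in place of chloro gives a 2.2-fold lower number from compound 2 to compound 3 (0.34 log units; beyond the scatter) and so the two groups are not interchangeable here. Methoxy still falls short of the unsubstituted ring, with a 3.2-fold higher number from compound 1 to compound 3 (0.51 log units; beyond the scatter) on top of the earlier 7.0-fold higher number from compound 1 to compound 2 (0.85 log units; beyond the scatter) and so, of the three compounds, compound 1 remains the strongest, with both groups on this aromatic carbon giving weaker inhibition than hydrogen. Nothing available here accounts for this order.

The compounds shown cover only hydrogen, chloro and methoxy at this one place on this one ring, so they cannot tell whether any group there can match or improve on hydrogen. An amine, a carboxylic acid, a fluorine atom or a longer chain such as ethoxy could each answer that, and the same two groups on other carbons of the ring remain an open question as well.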